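This account rests on a few compounds, and the source may have more. Where it says the series, first, only, none or still open, it means among the compounds named here.

Measured compounds:
Compound 1, `Cc1ccc2oc(/C=C/[S+](C)[O-])cc(=O)c2c1`: in a functional assay on DLD-1 cells (Homo sapiens) for cytotoxicity, with a stated time of 48 h (a lower number here means a stronger inhibitor, a higher number a weaker inhibitor), compound 1 gives 7000 nM.
Compound 2, `C[S+]([O-])/C=C/c1cc(=O)c2cc(C#N)ccc2o1`: in this assay compound 2 gives > 10000 nM, which is a limit of the assay and not a number.

Compound 2 thus stands at the weak end of the two values shown, and only a limit is known for it. Compound 3, `C[S+]([O-])/C=C/c1cc(=O)c2ccccc2o1`, differs from compound 2 by hydrogen in place of cyano on an aromatic carbon. For the measured compounds named here, the one measured step that bears on this position is an at least 1.4-fold higher number from compound 1 to compound 2 (0.15 log units; that floor lies within the scatter); its size is open at the upper end because of the limit of > 10000 nM in this assay, at which 1 of the 2 values shown sits. That step exchanged methyl for cyano, whereas the change from compound 2 to compound 3 removes the cyano without putting a carbon group in its place, so it is only a partial guide. The expectation is that compound 3 sits between the two measured values, close to compound 1, which means an expected step of an at least 1.2-fold lower number from compound 2 to compound 3 (0.09 log units; that floor lies within the scatter). On that basis compound 3 is estimated at 8000 nM in this assay, with a range from 3000 nM to 20000 nM.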

Compound 3, half-maximal inhibitory concentration: 8000 nM
Compound 3: middle estimate and measured number agree at the digits printed; measured number inside the range.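

The exchange of methyl for hydrogen on this aromatic carbon gives a 1.1-fold higher number from compound 1 to compound 3 (0.06 log units; within the scatter), so in this assay the number does not separate the two once the position is left bare, and a small carbon group at this place has no visible bearing on cytotoxicity in these cells. Taking the cyano away gives an at least 1.2-fold lower number from compound 2 to compound 3 (0.09 log units; that floor lies within the scatter), so what can be read of this change does not show that cyano and hydrogen differ at this position either. Compound 2 gives > 10000 nM, which is a limit of the assay and not a number, and the size of that step stays open at its upper end because of it: the limit of > 10000 nM in this assay, at which 1 of the 3 values shown sits.

The compounds shown leave open whether any group on this aromatic carbon, such as chlorine, a methoxy group, an amine or a carboxylic acid, would move the number beyond the scatter from compound 3 in either direction. Going by these compounds, all three compounds also carry the same sulfur-bearing side chain on the shared core, so what a change in that chain would do remains unknown.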